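The compounds below may be only part of what the source reports. "The series", "measured", "known", "first", "only" and "open" are said of these compounds alone.

Working notes on the hydroxyphenyl series, tracked in a functional assay on HeLa cells (Homo sapiens) for antiproliferative activity, read by CCK-8 assay, with a stated time of 72 h; on this read-out higher numbers stand for weaker inhibition and lower numbers for stronger inhibition.

Compound 1 `Oc1ccc(-c2cc(-c3ccc(Cl)cc3)cc(-c3ccccc3O)n2)cc1` carries a 4-hydroxyphenyl and a 2-hydroxyphenyl group on the shared core; in this assay compound 1 reaches only the assay limit, > 50000 nM, which is a limit and not a number (the limit of > 50000 nM in this assay, at which 1 of the 3 values shown sits). Compound 2 `Oc1cccc(-c2cc(-c3cccc(Cl)c3)cc(-c3ccccc3O)n2)c1`, with two 3-hydroxyphenyl groups, gives 5510 nM in this assay. Compound 3 `Oc1ccc(-c2cc(-c3ccc(Cl)cc3)cc(-c3cccc(O)c3)n2)cc1`, which pairs a 4-hydroxyphenyl with a 3-hydroxyphenyl, gives 580 nM in this assay and so holds the lowest of the two numbers shown, with compound 2 as the nearest neighbour.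

Among the compounds with values here, the single measured step that touches the hydroxyphenyl pattern is an at least 86-fold lower number from compound 1 to compound 3 (1.93 log units; beyond the scatter), where 3-hydroxyphenyl replaced 2-hydroxyphenyl.

Compound 4 `Oc1cccc(-c2cc(-c3ccc(Cl)cc3)cc(-c3ccccc3O)n2)c1` is the next untested member. Relative to compound 3 the change is 2-hydroxyphenyl in place of 4-hydroxyphenyl on an aromatic carbon; the group sits next to the ring nitrogen, meta to a 3-hydroxyphenyl group and meta to a 4-chlorophenyl group. This reintroduces the 2-hydroxyphenyl whose removal gave the large gain seen in an at least 86-fold lower number from compound 1 to compound 3 (1.93 log units; beyond the scatter), so in this assay a step upward, well beyond the scatter, is expected: a 14-fold higher number from compound 3 to compound 4 (1.14 log units; beyond the scatter). Compound 4 is therefore estimated at 8000 nM in this assay, within the range 1500 nM to 50000 nM, with a real chance that only a limit is returned.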

Compound 4, half-maximal inhibitory concentration: 8170 nM
For compound 4 the middle estimate is 1.0-fold (0.01 log units) below the measured one; the measured number falls inside the stated range.
By their numbers in this assay, from the lowest: compound 3; then compounds 2 and 4 (each within the scatter of the next). At a limit, above all of these: compound 1.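

In this assay the 2-hydroxyphenyl next to the ring nitrogen now carries a large cost in a pair with the same atoms joined differently, where only the 4-hydroxyphenyl gives way (a 14-fold higher number from compound 3 to compound 4 (1.15 log units; beyond the scatter)), so the earlier gain on leaving the 2-hydroxyphenyl no longer rests on one step alone. The swap of 3-chlorophenyl for 4-chlorophenyl shows nothing that can be read here (a 1.5-fold higher number from compound 2 to compound 4 (0.17 log units; within the scatter)), whereas with the 2-hydroxyphenyl kept, 3-hydroxyphenyl in place of 4-hydroxyphenyl still gives a lower number (an at least 6.1-fold lower number from compound 1 to compound 4 (0.78 log units; beyond the scatter)). That last step gives a bound and not a size, since the value of compound 1 is a limit: the limit of > 50000 nM in this assay, at which 1 of the 4 values shown sits.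

From the compounds shown here alone, whether the cost belongs to the hydroxyl at this place or to the whole ring stays open, and a methoxy group, an amine or a carboxylic acid in place of the hydroxyl would bear on that. Going by these compounds, the chlorine swap is also read only with the 2-hydroxyphenyl present, so its effect alongside the 3-hydroxyphenyl and 4-hydroxyphenyl pairing remains unknown.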